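A halogen swap on the anilino ring, from compound 1 to compound 4

A few compounds are considered here, and "the series" means these few. Any claim that something is new, unique, unknown or untested is made for them only; others in the source may bear on it.

The measurements come from a functional assay on HeLa cells (Homo sapiens) for inhibition, read by sulforhodamine B assay; on this read-out lower numbers stand for stronger inhibition and higher numbers for weaker inhibition. Compound 1 `O=C1C=C(Nc2ccc(I)cc2)C(=O)c2c1nc1n2[C@H]2OC[C@@H](O)[C@H]2OC1` gives 4070 nM in this assay. Compound 3 `O=C1C(Nc2ccc(Br)cc2)=CC(=O)c2c1nc1n2[C@H]2OC[C@@H](O)[C@H]2OC1` gives 5220 nM, and the numbers of compound 1 and compound 3 lie within the usual scatter of each other. Compound 2 `O=C1C(N2CCCCC2)=CC(=O)c2c1nc1n2[C@H]2OC[C@@H](O)[C@H]2OC1` reaches only a limit of the assay, > 16000 nM, so no number is known for it; this is the limit of > 16000 nM in this assay, at which 1 of the 3 values shown sits. For the measured compounds named here, the one measured step, an at least 3.0-fold lower number from compound 2 to compound 3 (0.48 log units; beyond the scatter), shows that a (4-bromophenyl)amino group in place of piperidin-1-yl gives a lower number.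

Compound 4 `O=C1C=C(Nc2cccc(F)c2)C(=O)c2c1nc1n2[C@H]2OC[C@@H](O)[C@H]2OC1` differs from compound 1 by 3-fluorophenyl in place of 4-iodophenyl on an amine nitrogen. Going by the values given here, no measured step compares one substituted phenylamino group with another, so the step from compound 2 to compound 3 does not bear directly on this change. With compound 1 and compound 3 so close, the expectation is a step of a 1.4-fold higher number from compound 1 to compound 4 (0.13 log units; within the scatter), that is, none beyond the scatter. Compound 4 is therefore estimated at 5500 nM, within a range from 2500 nM to 14000 nM.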

Compound 4, half-maximal inhibitory concentration: 6440 nM
Compound 4: middle estimate off by 1.2-fold (0.07 log units), on the low side; low and high end bracket the measured number.
By their numbers in this assay, from the lowest: compounds 1, 3 and 4 (each within the scatter of the next). At a limit, above all of these: compound 2.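

For the compounds shown here, this is the first direct comparison of two substituted phenylamino groups on this amine nitrogen. In this assay, replacing 4-iodophenyl with 3-fluorophenyl gives a 1.6-fold higher number from compound 1 to compound 4 (0.20 log units; within the scatter), so changing both the halogen and its place on the phenyl ring leaves no difference that can be told from ordinary assay variation. Because both changes come in a single step, their separate contributions cannot be read, and nothing measured here bears on why the two compounds fall so close together.

On these data alone, it remains open whether a phenyl ring with no halogen, or one carrying a methoxy group or a carboxylic acid, would also stay within this scatter. A simple alkyl amine or a morpholine on this ring carbon is also untested among the compounds shown.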